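The source may report more compounds than this note shows. Statements on the series, on what has been measured and on what is new or still open speak of the compounds shown alone.

Measured compounds:
- compound 1, `N#Cc1ccc(-c2nnc(-c3ccc(S(N)(=O)=O)cc3)o2)cc1`: 318 nM
- compound 2, `Cc1ccc(-c2nnc(-c3cccc(S(N)(=O)=O)c3)o2)cc1`: 571 nM
- compound 3, `N#Cc1ccc(C(=O)NNC(=O)c2ccc(S(N)(=O)=O)cc2)cc1`: 1170 nM

In an assay on cells for inhibition of Amine oxidase [flavin-containing] B (Homo sapiens), read by fluorescence and spectrophotometry, using microsomes, with a stated time of 20 min (a lower number here means a stronger inhibitor, a higher number a weaker inhibitor), compound 1 gives 318 nM, the lowest of the three numbers shown. Compound 2, at 571 nM, lies within the usual scatter of that figure, so the two cannot be told apart on these data. Compound 3, at 1170 nM, stands beyond the scatter and is the weaker inhibitor of the set. For the measured compounds named here, neither compound 2 nor compound 3 differs from compound 1 in a single place, so no one-change step between measured compounds is available.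

Compound 4, `NS(=O)(=O)c1ccc(-c2nnc(-c3ccc(F)cc3)o2)cc1`, is the next structure, and it does differ from compound 1 in one place: fluoro in place of cyano on an aromatic carbon. Going by the values given here, with no measured step of this kind to lean on, the account can only say that the change is small in count and that compound 1 carries the shared core through which the rest of the series is read. The step from compound 1 to compound 4 is therefore expected to be modest, and a 1.3-fold higher number from compound 1 to compound 4 (0.12 log units; within the scatter) is the estimated size, most likely not beyond the scatter. On that basis compound 4 is expected to give about 420 nM in this assay, within a range of 150 nM to 1200 nM.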

Compound 4, half-maximal inhibitory concentration: 79 nM
For compound 4 the middle estimate is 5.3-fold (0.73 log units) above the measured one; the measured number lies below the stated range.
By their numbers in this assay, from the lowest: compound 4; then compounds 1 and 2 (each within the scatter of the next); then compound 3.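

In this assay, the exchange of cyano for fluoro on an aromatic carbon, para to a large group, gives a 4.0-fold lower number from compound 1 to compound 4 (0.60 log units; beyond the scatter), a step beyond the scatter. For the compounds shown here, it is the first one-place step, and it shows what the earlier compounds could not: the group at this position alone can move the number by more than the scatter, and here the fluoro, with fewer heavy atoms and no hydrogen-bond acceptor, goes with the lower number. This remains a single step at a single position, and no measurement in hand bears on what lies behind it.

The compounds shown leave open whether the number keeps falling or turns back up with other groups at this position, such as chloro, methoxy, an amine or a carboxylic acid, so no trend can be drawn from one pair. They also leave open whether the same exchange of cyano for fluoro would give a step of similar size on the core of compound 3, where the shared ring is replaced by an open linker.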